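A few compounds are considered here, and "the series" means these few. Any claim that something is new, unique, unknown or untested is made for them only; others in the source may bear on it.

Measured in a toxicity assay on MDCK cells (Canis lupus familiaris) for cytotoxicity, read by CCK-8 assay, with a stated time of 48 h; on this read-out higher numbers stand for lower toxicity in this test and lower numbers for higher toxicity in this test:
compound 1 `CCOc1ccc(C(=O)NNc2c(Br)cccc2Br)cc1`: > 100000 nM
compound 2 `O=C(NNc1c(Br)cccc1Br)c1ccc(OCC(F)(F)F)cc1`: > 100000 nM
compound 3 `CCOc1ccc(C(=O)NNc2c(F)cccc2F)cc1`: > 100000 nM

Each entry is a limit, not a number. Compound 3 stands at > 100000 nM, which is a limit. Within the data shown here, the series so far shows only (the limit of > 100000 nM in this assay, at which 3 of the 3 values shown sit).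

Compound 4 `COc1ccc(C(=O)NNc2c(F)cccc2F)cc1` follows from compound 3 by one change: hydrogen in place of methyl on a saturated chain carbon bound to an oxygen on an aromatic ring, ethoxy to methoxy. Among the measured compounds shown here, the one measured step at this place is a step that the two limits leave unreadable from compound 1 to compound 2, so it offers no size to carry over. With compound 3 giving > 100000 nM, no step beyond the scatter is expected in this assay. The expected step is a number no higher from compound 3 to compound 4 (the limit leaves the size open). For compound 4 the estimate is 100000 nM, with an expected range of 50000 nM to 200000 nM.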

Compound 4, half-maximal cytotoxic concentration: > 100000 nM
Compound 4: only a limit was reported; the forecaster's own chance of this, stated with the estimate: 85%; the middle value lies on the limit itself.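

Among these compounds, compound 3 and compound 4 both stand as limits, not numbers, in this assay, so no step between them can be read. The compounds shown leave open the actual half-maximal cytotoxic concentration of each compound, and so the size of any step between them: the limit of > 100000 nM in this assay, at which 4 of the 4 values shown sit.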